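Shorter ring ether on a weak chalcone-like series

The source may report more compounds than this note shows. Statements on the series, on what has been measured and on what is new or still open speak of the compounds shown alone.

Compound 1 `CC(C)CCCOc1cccc(O)c1C(=O)/C=C/c1ccc(O)cc1`: 3630 nM
Compound 2 `CC(C)=CCOc1cccc(O)c1C(=O)/C=C/c1ccc(O)cc1`: > 30000 nM, a limit
Compound 3 `O=C(/C=C/c1ccc(O)cc1)c1c(O)cccc1OCCC1CCCCC1`: > 30000 nM, a limit

All three were tested in a functional assay on ACHN cells (Homo sapiens) for antiproliferative activity, read by sulforhodamine B assay; on this read-out lower numbers stand for stronger inhibition of growth and higher numbers for weaker inhibition of growth. Compound 3 stands at the limit of > 30000 nM in this assay, at which 2 of the 3 values shown sit. Compound 4 `O=C(/C=C/c1ccc(O)cc1)c1c(O)cccc1OCC1CCCC1` carries cyclopentyl in place of cyclohexylmethyl on a saturated chain carbon bound to an oxygen on an aromatic ring. Within the data shown here, two steps bear on this, an at least 8.2-fold higher number from compound 1 to compound 3 (0.91 log units; beyond the scatter) and an at least 8.2-fold higher number from compound 1 to compound 2 (0.91 log units; beyond the scatter), and both show that the number rises when the chain of compound 1 is altered. The step that the two limits leave unreadable from compound 2 to compound 3 adds no size. Compound 4 is therefore expected to remain weak, with at most a modest drop in the number. The expected step is an at least 1.3-fold lower number from compound 3 to compound 4 (0.13 log units; that floor lies within the scatter). Compound 4 is estimated at 22000 nM, with an expected range of 7000 nM to 45000 nM.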

Compound 4, concentration for 50% growth inhibition: 3510 nM
Compound 4: middle estimate off by 6.3-fold (0.80 log units), on the high side, and the stated range ends above it.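

Cyclopentyl at this place gives an at least 8.5-fold lower number from compound 3 to compound 4 (0.93 log units; beyond the scatter) and an at least 8.5-fold lower number from compound 2 to compound 4 (0.93 log units; beyond the scatter) and so shows that a ring on this saturated chain carbon need not leave the number at the limit. Against the isopentyl of compound 1 it gives a 1.0-fold lower number from compound 1 to compound 4 (0.01 log units; within the scatter) and so the open chain and the ring stand level here. Compound 2 and compound 3 are each given only as a limit: the limit of > 30000 nM in this assay, at which 2 of the 4 values shown sit.

The compounds shown leave open how a cyclobutyl or a cyclohexyl on this carbon would read. They also leave open whether a longer chain ending in cyclopentyl, or an amine in the ring, would hold this level.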